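Adding a Chloro Group to the Benzyl Arm

The source may hold more compounds than are shown below. What is called first, only, known or untested is meant among the compounds shown, and "the series" means these compounds.

Measured so far:
Compound 1 `Cc1ccc(-c2nn(-c3ccccc3)cc2C(=O)NOCc2ccccc2Cl)cc1` gives 38700 nM in an ADME assay on HEK-293T cells (Homo sapiens) for antiproliferative activity, read by MTT assay, with a stated time of 48 h, in the presence of a further agent that is not named here; on this read-out lower numbers stand for higher toxicity in this test and higher numbers for lower toxicity in this test.
Compound 2 `COc1ccc(-c2nn(-c3ccccc3)cc2C(=O)NOCc2ccccc2)cc1` gives 201000 nM.
Compound 3 `O=C(NOCc1ccccc1)c1cn(-c2ccccc2)nc1-c1ccc(Cl)cc1` gives 51900 nM.

Compound 3 stands second highest of the three numbers, nearest to compound 1 and separated from compound 2 by the step of a 3.9-fold lower number from compound 2 to compound 3 (0.59 log units; beyond the scatter). Compound 4 `O=C(NOCc1ccccc1Cl)c1cn(-c2ccccc2)nc1-c1ccc(Cl)cc1` differs from compound 3 in one place: chloro in place of hydrogen on an aromatic carbon. Among the measured compounds shown here, no measured step bears directly on this change. Compound 1 carries the same 2-chlorobenzyl arm but differs from compound 3 in a second place too, and its number sits within the scatter of that of compound 3, which is all the two values show. No step beyond the scatter is therefore expected in this assay. Compound 4 is estimated at 45000 nM, ranging from 15000 nM to 135000 nM, an expected step of a 1.2-fold lower number from compound 3 to compound 4 (0.06 log units; within the scatter).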

Compound 4, half-maximal cytotoxic concentration: 129000 nM
Compound 4: the middle estimate sits 2.9-fold (0.46 log units) below what was measured; low and high end bracket the measured number.
By their numbers in this assay, from the lowest: compounds 1 and 3 (each within the scatter of the next); then compounds 4 and 2 (each within the scatter of the next).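

In this assay the change from benzyl to 2-chlorobenzyl brings a 2.5-fold higher number from compound 3 to compound 4 (0.40 log units; beyond the scatter) and so shows that this position responds, here toward lower toxicity in this test. With the 2-chlorobenzyl arm kept, swapping the methyl group for a chloro group brings a 3.3-fold higher number from compound 1 to compound 4 (0.52 log units; beyond the scatter) and so shows that this arm alone does not set the number. Nothing measured here explains either step.

From the compounds shown here alone, whether an amine or a carboxylic acid on the benzyl arm would shift the number in the same direction remains open.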